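This account rests on a few compounds, and the source may have more. Where it says the series, first, only, none or still open, it means among the compounds named here.

Of the compounds shown here, three sharing one core have been measured in an assay on HEK293 cells for agonist activity at Toll-like receptor 2 (Homo sapiens); a higher number here means that more compound is needed for the effect, a lower number that less compound is needed. Compound 1 `CCCCCCCCCCCC(=O)OC[C@H](CSC[C@@H](N)C(=O)NCCCC(C)(C)CO)OC(=O)CCCCCCCCCCC` gives 30700 nM. Compound 2 `CCCCCCCCCCCC(=O)OC[C@H](CSC[C@@H](N)C(=O)NC(C)c1ccc(O)cc1)OC(=O)CCCCCCCCCCC` gives 2890 nM, while compound 3 `CCCCCCCCCCCC(=O)OC[C@H](CSC[C@@H](N)C(=O)NC(C)CCC(C)C)OC(=O)CCCCCCCCCCC` gives 190 nM, the lowest of the three numbers. The steps between them are all large: an 11-fold lower number from compound 1 to compound 2 (1.03 log units; beyond the scatter), a 160-fold lower number from compound 1 to compound 3 (2.21 log units; beyond the scatter), and a 15-fold lower number from compound 2 to compound 3 (1.18 log units; beyond the scatter). In each case the group on the amide-type nitrogen in compounds 1 and 2 carries a hydroxy group, and compound 3, whose group carries none, stands lowest.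

Compound 4 `CCCCCCCCCCCC(=O)OC[C@H](CSC[C@@H](N)C(=O)NCCCN)OC(=O)CCCCCCCCCCC` has not yet been measured. It differs from compound 3 in one place: 3-aminopropyl in place of 1,4-dimethylpentyl on an amide-type nitrogen. The measured steps that bear on this are the two that lead away from compound 3 to compounds 1 and 2, where a group bringing a hydrogen-bond donor and acceptor went with a much higher number. A large step upward is therefore expected, estimated as a 42-fold higher number from compound 3 to compound 4 (1.62 log units; beyond the scatter). For compound 4 the estimate is 8000 nM, with a range from 1500 nM to 40000 nM.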

Compound 4, half-maximal effective concentration: 1960 nM
Compound 4: middle estimate off by 4.1-fold (0.61 log units), on the high side; the measured number falls inside the stated range.
By their numbers in this assay, from the lowest: compound 3; then compounds 4 and 2 (each within the scatter of the next); then compound 1.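

Replacing 1,4-dimethylpentyl with 3-aminopropyl on the amide-type nitrogen is a large step (a 10-fold higher number from compound 3 to compound 4 (1.01 log units; beyond the scatter)), so the rise seen with hydroxy-bearing groups also appears with an amino group, and compound 3, which carries neither, stays lowest of the four. The groups carrying one do not all sit at one level, however: compound 2 and compound 4 lie within the scatter of each other (a 1.5-fold lower number from compound 2 to compound 4 (0.17 log units; within the scatter)), while amino in place of 1-(hydroxymethyl)-1-methylethyl on the chain is a large change (a 16-fold lower number from compound 1 to compound 4 (1.19 log units; beyond the scatter)). No measurement at hand gives a reason for these steps.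

As far as these compounds go, the step to compound 4 changes both the chain and its end group, so the share of each remains open. A plain propyl group would separate the two, and a carboxylic acid at the chain end would show whether other end groups behave like the amine.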